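This account rests on a few compounds, and the source may have more. Where it says the series, first, only, none or still open, it means among the compounds named here.

Working notes on the series. All compounds share the core of compound 1 `FC(F)(F)c1ccc(CSc2nc(Nc3ccccc3Cl)c3ccccc3n2)cc1`. In a functional assay on MCF7 cells (Homo sapiens) for cytotoxicity, read by MTT assay, with a stated time of 72 h (on this read-out lower numbers stand for stronger inhibition and higher numbers for weaker inhibition), compound 1 reaches only a limit, > 50000 nM. Compound 2 `Cc1ccccc1Nc1nc(SCc2ccc(C(F)(F)F)cc2)nc2ccccc12` gives 37500 nM in this assay. For the measured compounds named here, the single measured step, an at least 1.3-fold lower number from compound 1 to compound 2 (0.12 log units; that floor lies within the scatter), is methyl in place of chloro on an aromatic carbon and does not clear the scatter. Going by the values given here, compound 2 therefore stands as the only number in this assay. The other value in the series is a limit, (the limit of > 50000 nM in this assay, at which 1 of the 2 values shown sits).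

Compound 3 `O=[N+]([O-])c1ccc(Nc2nc(SCc3ccc(C(F)(F)F)cc3)nc3ccccc23)cc1` differs from compound 2 by 4-nitrophenyl in place of 2-methylphenyl on a nitrogen on an aromatic ring. Among the compounds with values here, no measured step touches the group on the ring nitrogen, so nothing in the data sets a direction for this change, and the small step on the aromatic carbon offers no guide. The expected step in this assay is a 1.1-fold higher number from compound 2 to compound 3 (0.03 log units; within the scatter), which lies within the scatter. Compound 3 is accordingly estimated at 40000 nM, with a range from 12000 nM to 50000 nM.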

Compound 3, half-maximal inhibitory concentration: 17900 nM
Estimate against measurement, compound 3: 2.2-fold (0.35 log units) above, within the range that was stated.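

For the compounds shown here, exchanging 2-methylphenyl for 4-nitrophenyl on the nitrogen gives a 2.1-fold lower number from compound 2 to compound 3 (0.32 log units; beyond the scatter) in this assay, the first change to clear the scatter with a measured number at both ends. The group on this nitrogen can therefore shift the read-out, which the methyl-for-chloro step on the aromatic carbon did not show. Set against the 2-chlorophenyl group, the change reads an at least 2.7-fold lower number from compound 1 to compound 3 (0.44 log units; beyond the scatter), but that step gives only a floor, as compound 1 stands at a limit: the limit of > 50000 nM in this assay, at which 1 of the 3 values shown sits.

The groups 2-methylphenyl and 4-nitrophenyl differ in both the substituent and its place on the ring, and the compounds shown do not separate these two differences. Also open, going by these compounds, is how an amine, as 4-aminophenyl, or a carboxylic acid, as 4-carboxyphenyl, would read on the same nitrogen.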